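This account rests on a few compounds, and the source may have more. Where it says the series, first, only, none or still open, it means among the compounds named here.

Measured so far in a functional assay on MDA-MB-435S cells (Homo sapiens) for antiproliferative activity, read by MTT assay, with a stated time of 72 h; on this read-out lower numbers stand for stronger inhibition and higher numbers for weaker inhibition:
compound 1 `O=c1cc(CSC(=S)N2CCCCC2)oc2cc(Cl)ccc12` gives 3000 nM
compound 2 `COc1ccc2oc(CSC(=S)N(C(C)C)C(C)C)cc(=O)c2c1` gives 22100 nM
compound 3 `CC(C)N(C(=S)SCc1cc(=O)c2ccc(Cl)cc2o1)C(C)C` gives > 25000 nM

The value for compound 3 is not a number but a limit of the assay, namely (the limit of > 25000 nM in this assay, at which 1 of the 3 values shown sits). Compound 2 sits highest of the two numbers recorded; its nearest neighbour is compound 1, at a lower number.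

Compound 3 and compound 1 differ in one place, (piperidin-1-yl in place of diisopropylamino on a thiocarbonyl carbon). That change gave an at least 8.3-fold lower number from compound 3 to compound 1 (0.92 log units; beyond the scatter). The difference between the cores of compound 2 and compound 3 is not broken down here.

Compound 4 `COc1ccc2oc(CSC(=S)N3CCCCC3)cc(=O)c2c1` has not been measured in this assay. It differs from compound 2 by piperidin-1-yl in place of diisopropylamino on a thiocarbonyl carbon, which is the same change, at the same place, as that from compound 3 to compound 1. Since the measured change produced an at least 8.3-fold lower number from compound 3 to compound 1 (0.92 log units; beyond the scatter), a comparable step is expected here, about an 8.2-fold lower number from compound 2 to compound 4 (0.91 log units; beyond the scatter), though the measured step is itself only a lower bound because compound 3 sits at the limit of > 25000 nM in this assay, at which 1 of the 3 values shown sits. Compound 4 is accordingly estimated at 2700 nM, with the likely range taken as 900 nM to 9000 nM.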

Compound 4, half-maximal inhibitory concentration: 1500 nM
Compound 4: middle estimate off by 1.8-fold (0.26 log units), on the high side; the measured number falls inside the stated range.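

In this assay, piperidin-1-yl in place of diisopropylamino on a thiocarbonyl carbon gave a 15-fold lower number from compound 2 to compound 4 (1.17 log units; beyond the scatter). The change therefore carried over in direction between the two cores, with the step beyond the scatter on each: the same change on two cores in this assay, an at least 8.3-fold lower number (0.92 log units; beyond the scatter) from compound 3 to compound 1 and a 15-fold lower number (1.17 log units; beyond the scatter) from compound 2 to compound 4; the limit leaves it open whether they differ

As far as these compounds go, compound 3 gives > 25000 nM, which is a limit of the assay and not a number, so the size of the step on its core remains unknown, and the series does not show that the change is worth the same amount on both cores or that it would carry to a third.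

From the compounds shown here alone, it remains open whether the lower numbers belong to piperidin-1-yl in particular or would also appear with another amine on the thiocarbonyl carbon, such as morpholin-4-yl, pyrrolidin-1-yl or dimethylamino. Also open, going by these compounds, is whether the same step would hold on a core carrying a different group, such as a nitrile or a trifluoromethyl group, in place of those on the cores of compound 1 and compound 4.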